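A few compounds are considered here, and "the series" means these few. Any claim that something is new, unique, unknown or untested is made for them only; others in the source may bear on it.

Of the compounds shown here, three have so far been tested in a functional assay on the whole organism for antagonist activity, with Mus musculus as the target; on this read-out higher numbers stand for an effect only at larger amounts of compound and lower numbers for an effect already at smaller amounts. Compound 1, `O=C1OCCN1CC#CCn1ccnc1`, joins a five-membered aromatic ring with 2 nitrogen through a short linker containing a triple bond to a ring-shaped end group. In this assay compound 1 gives only a limit, > 100 mg/kg, so its true number is not known. Compound 2, `Cc1cncn1CC#CCN1CCOC1=O`, differs from compound 1 in one place: methyl in place of hydrogen on an aromatic carbon. In this assay compound 2 gives 37 mg/kg. The step is an at least 2.7-fold lower number from compound 1 to compound 2 (0.43 log units; beyond the scatter), and it can be given only as a lower bound because the limit of > 100 mg/kg in this assay, at which 1 of the 3 values shown sits, is where compound 1 sits.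

Compound 3, `CN(C)C(=O)N(C)CC#CCn1ccnc1`, keeps the same aromatic ring and linker but ends in an open-chain group instead of a ring; the difference between the two cores is not broken down here. In this assay compound 3 gives 11.8 mg/kg, the lower of the two numbers measured.

Compound 4, `Cc1cncn1CC#CCN(C)C(=O)N(C)C`, has not yet been measured. It stands to compound 3 exactly as compound 2 stands to compound 1, the same change at the same place: methyl in place of hydrogen on an aromatic carbon. If the methyl acts on the open-chain core as it did on the ring-shaped one, the expected step is a 2.6-fold lower number from compound 3 to compound 4 (0.42 log units; beyond the scatter), judged against the earlier at least 2.7-fold lower number from compound 1 to compound 2 (0.43 log units; beyond the scatter), which rests on a limit and may understate the gain. Compound 4 is therefore estimated at 4.5 mg/kg, most likely between 1.5 mg/kg and 12 mg/kg.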

Compound 4, dose for half-maximal effect: 9.7 mg/kg
Compound 4: the middle estimate sits 2.2-fold (0.33 log units) below what was measured, within the range that was stated.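

In this assay, methyl in place of hydrogen on an aromatic carbon gives a 1.2-fold lower number from compound 3 to compound 4 (0.09 log units; within the scatter), so on the open-chain core this change brings no effect that can be told apart from the usual scatter of the measurement. This shows that a step beyond the scatter on the ring-shaped core, an at least 2.7-fold lower number from compound 1 to compound 2 (0.43 log units; beyond the scatter), does not guarantee a clear step when the same change is moved to another core in this series. It does not show that the methyl really acts differently on the two cores, and the value of compound 1, which is needed for that comparison, is a limit and not a number, so the question stays unsettled: the same change on two cores in this assay, an at least 2.7-fold lower number (0.43 log units; beyond the scatter) from compound 1 to compound 2 and a 1.2-fold lower number (0.09 log units; within the scatter) from compound 3 to compound 4; the limit leaves it open whether they differ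

For the compounds shown here, with only two matched pairs, both read in this assay, no general rule for this methyl can be drawn, and it remains open how the change would behave on a third core, for instance one ending in an amine or a carboxylic acid. Also open, as far as these compounds go, is whether an ethyl group or a chlorine atom in the same place on the ring would give a step like that of methyl on either core.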